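This account rests on a few compounds, and the source may have more. Where it says the series, first, only, none or still open, it means among the compounds named here.

Compound 1 `CC#C[C@@H](Cc1nnn[nH]1)c1ccc(OCc2ccc3scc(-c4cc(OCCOC)ccc4C)c3c2)cc1` stands at the higher of the two numbers recorded so far. In a functional assay on cells for agonist activity at Free fatty acid receptor 1 (Homo sapiens), read by FLIPR and calcium flux (on this read-out higher numbers stand for an effect only at larger amounts of compound and lower numbers for an effect already at smaller amounts), compound 1 gives 85 nM, while compound 2 `CC#C[C@@H](Cc1nnn[nH]1)c1ccc(OCc2cc(F)c3scc(-c4ccc(OC)cc4C)c3c2)cc1` gives 10 nM, a gap that lies beyond the usual scatter. Compound 3 `CC#C[C@@H](Cc1nnn[nH]1)c1ccc(OCc2ccc3scc(C4CC4)c3c2)cc1` has not yet been measured. It differs from compound 1 in one place: cyclopropyl in place of 5-(2-methoxyethoxy)-2-methylphenyl on an aromatic carbon. For the measured compounds named here, the group that leaves is larger than the group that enters, and no measured pair shows a change of this kind, so the expected step in this assay rests on the change itself and on where compound 1 stands. Compound 3 is expected to move toward a higher number than compound 1 by a 7.1-fold higher number from compound 1 to compound 3 (0.85 log units; beyond the scatter), a step beyond the scatter. The value estimated for compound 3 in this assay is 600 nM, with a range from 150 nM to 3000 nM.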

Compound 3, half-maximal effective concentration: 858 nM
Compound 3: middle estimate off by 1.4-fold (0.16 log units), on the low side; measured number inside the range.
By their numbers in this assay, from the lowest: compound 2; then compound 1; then compound 3.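

In this assay, for the compounds shown here, the change on this aromatic carbon, two ring bonds from the ring sulfur, gives a 10-fold higher number from compound 1 to compound 3 (1.00 log units; beyond the scatter), the first direct reading of this position. It shows that the position is not indifferent to its group: with 5-(2-methoxyethoxy)-2-methylphenyl, 12 heavy atoms, replaced by cyclopropyl, 3 heavy atoms, the effect needs a larger amount of compound, yet compound 3 still gives a measured number of 858 nM. Nothing measured here accounts for the size of this step.

Going by these compounds alone, the single step changes the ring, the methyl group and the 2-methoxyethoxy chain together, so it cannot be divided among them. The compounds shown leave open how a plain phenyl, or a 2-methylphenyl without the 2-methoxyethoxy chain, would stand on this carbon.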